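This account rests on a few compounds, and the source may have more. Where it says the series, first, only, none or still open, it means among the compounds named here.

Measured in a functional assay on PC-3 cells (Homo sapiens) for cytotoxicity, read by MTT assay, with a stated time of 72 h; on this read-out lower numbers stand for stronger inhibition and higher numbers for weaker inhibition:
compound 1 `COc1ccc(S(=O)(=O)c2nc3ccccc3nc2Nc2cc(OC)cc(OC)c2)cc1` gives 6220 nM
compound 2 `COc1ccc(S(=O)(=O)c2nc3ccccc3nc2Nc2ccc(N)cc2)cc1` gives 9640 nM

For the measured compounds named here, compound 2 stands level with compound 1 in this assay: the only step, a 1.5-fold higher number from compound 1 to compound 2 (0.19 log units; within the scatter), lies within the scatter, so the two compounds are not separated.

Compound 3 `Nc1ccc(Nc2nc3ccccc3nc2S(=O)(=O)c2ccc(F)cc2)cc1` differs from compound 2 by fluoro in place of methoxy on an aromatic carbon, on the six-membered aromatic ring of carbon only, para to a large group. Going by the values given here, no measured step bears on this change. Among the compounds with values here, the single step available, a 1.5-fold higher number from compound 1 to compound 2 (0.19 log units; within the scatter), concerns the group on the nitrogen of the shared core, a different position, and it was itself within the scatter. There is thus no measured basis for a shift in either direction, and the expectation is a step of a 1.0-fold lower number from compound 2 to compound 3 (0.01 log units; within the scatter) that stays within the scatter. The estimate for compound 3 in this assay is 9500 nM, in the range 4000 nM to 22000 nM.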

Compound 3, half-maximal inhibitory concentration: 2050 nM
For compound 3 the middle estimate is 4.6-fold (0.67 log units) above the measured one; the measured number lies below the stated range.
By their numbers in this assay, from the lowest: compound 3; then compounds 1 and 2 (each within the scatter of the next).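

In this assay, for the compounds shown here, fluoro in place of methoxy, on an aromatic carbon para to a large group, gives a 4.7-fold lower number from compound 2 to compound 3 (0.67 log units; beyond the scatter), the first step to lie beyond the scatter. The earlier step, a 1.5-fold higher number from compound 1 to compound 2 (0.19 log units; within the scatter), concerned the group on the nitrogen and did not separate its two compounds, whereas this exchange of one small substituent on the 4-methoxyphenyl ring does move the read-out, though only modestly. No measurement bearing on the reason for this shift is available.

A single pair cannot show whether the lower number belongs to fluoro itself or to the loss of methoxy; chloro, trifluoromethyl or plain hydrogen at this place would distinguish the two. Going by these compounds, whether the same exchange holds with 3,5-dimethoxyphenyl on the nitrogen, rather than 4-aminophenyl, also remains open.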